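Trading a Propyl Chain for a Phenyl Ring

A few compounds are considered here, and "the series" means these few. Any claim that something is new, unique, unknown or untested is made for them only; others in the source may bear on it.

For the measured compounds named here, compound 2 `CCCc1nnc2sc(-c3cccc(F)c3)nn12` gives 35% in an assay for inhibition of histone-lysine N-methyltransferase, H3 lysine-79 specific (Homo sapiens), with stated times of 15 min and 120 min, tested at 50 uM (a lower number here means less inhibition, a higher number more inhibition at the concentration tested (going by the name of the read-out)), the higher of the two numbers so far, although compound 1 `Fc1cccc(-c2nn3c(Cc4ccccc4)nnc3s2)c1`, at 33%, lies within the scatter of it: the step of a number 2 percentage points higher from compound 1 to compound 2 (within the scatter) was within the scatter. Compound 3 `Fc1cccc(-c2nn3c(-c4ccccc4)nnc3s2)c1` differs from compound 2 by phenyl in place of propyl on an aromatic carbon. Going by the values given here, the single measured step, which swapped a phenyl-bearing chain for a plain chain, is the only one that bears on this change, and it did not move the number beyond the scatter, so no step beyond the scatter is expected here either. Compound 3 is therefore expected to give 34%, within 18% to 50%, an expected step of a number 1 percentage points lower from compound 2 to compound 3 (within the scatter).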

Compound 3, a percentage reported as inhibition, at one concentration (the size of the read-out at that concentration, not a potency): 15%
Compound 3: middle estimate off by 19 percentage points, on the high side; measured number outside the range, below it.
By their numbers in this assay, from the lowest: compound 3; then compounds 1 and 2 (each within the scatter of the next).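

In this assay, this position on an aromatic carbon does respond to the group placed there: phenyl in place of propyl gives a number 20 percentage points lower from compound 2 to compound 3 (beyond the scatter), and phenyl in place of benzyl gives a number 18 percentage points lower from compound 1 to compound 3 (beyond the scatter). Propyl and benzyl sit within the scatter of each other, so among these three compounds only the phenyl ring bound directly to the core stands apart. No measurement here gives a reason for this drop. Still open, on these data alone, is whether a longer chain than propyl or an amine on that carbon would hold the number, and whether a directly bound cyclohexyl ring would lower it as phenyl does.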